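This account rests on a few compounds, and the source may have more. Where it says the series, first, only, none or still open, it means among the compounds named here.

Compound 1 `COc1ccc(CNC(=O)/C(C#N)=C/c2ccc[nH]2)cc1` gives > 50000 nM, which is a limit of the assay rather than a number. Compound 2 `COc1ccc(CNC(=O)/C(C#N)=C/c2ccc(Br)o2)cc1` gives 12000 nM. Compound 3 `COc1ccc(CNC(=O)/C(C#N)=C/c2ccc(C)cc2)cc1` gives 34000 nM.

In a functional assay on DU-145 cells (Homo sapiens) for inhibition, read by MTT assay, with a stated time of 72 h (on this read-out higher numbers stand for weaker inhibition of growth and lower numbers for stronger inhibition of growth), compound 3 holds the highest of the two numbers reported, and the step of a 2.8-fold higher number from compound 2 to compound 3 (0.45 log units; beyond the scatter) lies beyond the scatter. Compound 4 `COc1ccc(CNC(=O)/C(C#N)=C/c2ccc(Cl)cc2)cc1` differs from compound 3 only by chloro in place of methyl on an aromatic carbon. Among the compounds with values here, none of the measured steps bears directly on such a change: an at least 4.1-fold lower number from compound 1 to compound 2 (0.61 log units; beyond the scatter), an at least 1.4-fold lower number from compound 1 to compound 3 (0.16 log units; that floor lies within the scatter) and a 2.8-fold higher number from compound 2 to compound 3 (0.45 log units; beyond the scatter) each exchange the whole ring on the double-bonded chain carbon, not a single group on one ring. Within the data shown here, with no comparable step to draw on, the change is expected to give no step beyond the scatter, a 1.4-fold lower number from compound 3 to compound 4 (0.13 log units; within the scatter). Compound 4 is therefore estimated at 25000 nM, in the range 8000 nM to 60000 nM.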

Compound 4, concentration for 50% growth inhibition: 7000 nM
For compound 4 the middle estimate is 3.6-fold (0.55 log units) above the measured one; the whole stated range lies above it.
By their numbers in this assay, from the lowest: compounds 4 and 2 (each within the scatter of the next); then compound 3. At a limit, above all of these: compound 1.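

In this assay, within the data shown here, chloro in place of methyl on an aromatic carbon gives a 4.9-fold lower number from compound 3 to compound 4 (0.69 log units; beyond the scatter), showing for the first time that a single group at this place, with the ring kept, moves the number beyond the scatter. With chloro in this place, the change of ring gives a 1.7-fold lower number from compound 2 to compound 4 (0.23 log units; within the scatter), so 4-chlorophenyl and 5-bromofuran-2-yl are not separated here. The 4-chlorophenyl ring also gives an at least 7.1-fold lower number from compound 1 to compound 4 (0.85 log units; beyond the scatter), a step that starts from a limit of the assay: the limit of > 50000 nM in this assay, at which 1 of the 4 values shown sits.

The compounds shown leave open how fluoro, methoxy or an amine would fare at this same place. They also leave open whether chloro elsewhere on the ring would give a similar step.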